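Replacing 2-methyl-4-nitrophenyl with 2-aminophenyl on compound 2

A few compounds are considered here, and "the series" means these few. Any claim that something is new, unique, unknown or untested is made for them only; others in the source may bear on it.

Compound 1 `CCOC(=O)C1=C(C)NC(=O)NC1c1cn(C(=O)CNc2ccc([N+](=O)[O-])cc2C)c2ccccc12` in a physicochemical assay for lipophilicity (on this read-out lower numbers stand for lower lipophilicity and higher numbers for higher lipophilicity), gives 1.94
Compound 2 `CCOC(=O)C1=C(C)NC(=S)NC1c1cn(C(=O)CNc2ccc([N+](=O)[O-])cc2C)c2ccccc12` in this assay gives 3.34

Of these two compounds, compound 2 stands highest in this assay with 3.34 as its value, and the gap down to compound 1 (1.94) lies beyond the scatter. The next compound to be measured is compound 3 `CCOC(=O)C1=C(C)NC(=S)NC1c1cn(C(=O)CNc2ccccc2N)c2ccccc12`, which keeps the rest of compound 2 and carries 2-aminophenyl in place of 2-methyl-4-nitrophenyl on an amine nitrogen. Among the compounds with values here, no measured pair shows this change, so the forecast rests on the structural change alone and remains a judgement. A clear fall beyond the scatter is expected, and the estimated step is a number 1.04 log units lower from compound 2 to compound 3 (beyond the scatter) in size. The estimate for compound 3 is 2.3 (expected range 1.6 to 3).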

Compound 3, partition coefficient: 2.14
The estimate for compound 3 lay 0.16 log units above the measured number, and the stated range covers the measured number.
By their numbers in this assay, from the lowest: compounds 1 and 3 (each within the scatter of the next); then compound 2.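

In this assay, putting 2-aminophenyl in place of 2-methyl-4-nitrophenyl on the amine nitrogen gives a number 1.20 log units lower from compound 2 to compound 3 (beyond the scatter), a large step. Within the data shown here, the earlier compounds all carried 2-methyl-4-nitrophenyl at this place, so this is the first sign that the read-out responds to the group on this nitrogen, and it does so with the thiocarbonyl form of the shared core kept in place. No measurement on hand ties the step to any one feature of the exchange.

As far as these compounds go, the exchange removes the methyl and the nitro group and adds an amine in a single move, so the share of each remains open. Also open, from the compounds shown here alone, is where this assay would fall with plain phenyl, or with a methoxy group or a carboxylic acid on the ring, on this nitrogen, and whether the step would repeat on the carbonyl form of the core.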